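A few compounds are considered here, and "the series" means these few. Any claim that something is new, unique, unknown or untested is made for them only; others in the source may bear on it.

Measured compounds:
compound 1 `CCOC(=O)[C@@H](N)CCC(=O)NCCSC(=O)C(C)(C)C`, which in an ADME assay on HaCaT cells (Homo sapiens) for cytotoxicity, read by MTT assay, with a stated time of 48 h (on this read-out higher numbers stand for an effect only at larger amounts of compound and lower numbers for an effect already at smaller amounts), gives 228000 nM
compound 2 `CCCCOC(=O)[C@@H](N)CCC(=O)NCCSC(=O)C(C)(C)C`, which in this assay gives 102000 nM

Compound 2 stands at the lowest of the two numbers; its nearest neighbour is compound 1, and the step of a 2.2-fold lower number from compound 1 to compound 2 (0.35 log units; beyond the scatter) is modest but beyond the scatter. That step sits at the ester end of the shared core, ethyl in place of hydrogen on a saturated chain carbon, two bonds along the chain from an oxygen next to a carbonyl group.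

Compound 3 `CCCCOC(=O)[C@@H](N)CCC(=O)NCCSC(C)=O` is the compound to be measured next. Against compound 2 it differs by methyl in place of tert-butyl on a carbonyl carbon. Going by the values given here, no measured step touches the carbonyl carbon whose other neighbour is sulfur; the one recorded step concerns a different end of the molecule and a different kind of change, so it gives no direction for this one. Only its size is of use as a scale. The step of a 1.2-fold higher number from compound 2 to compound 3 (0.07 log units; within the scatter) is therefore expected to be small, within or near the scatter, with no direction favoured. For compound 3 the estimate in this assay is 120000 nM, with a range from 50000 nM to 300000 nM.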

Compound 3, half-maximal effective concentration: 563000 nM
Estimate against measurement, compound 3: 4.7-fold (0.67 log units) below, and the stated range ends below it.
By their numbers in this assay, from the lowest: compound 2; then compound 1; then compound 3.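

Changing the group on a carbonyl carbon whose other neighbours are sulfur matters in this assay: replacing tert-butyl with methyl gives a 5.5-fold higher number from compound 2 to compound 3 (0.74 log units; beyond the scatter), so this end of the shared core is not silent on this read-out, and the smaller acyl group needs larger amounts of compound for an effect. Across the two steps now available, the compound with the larger group at the changed place has the lower number, and neither step goes against this, although the pattern rests on only three compounds and on changes at different ends of the molecule. Nothing measured here gives a reason for the shift in cytotoxicity from tert-butyl to methyl.

The compounds shown leave open whether the number moves gradually or abruptly with intermediate groups on this carbonyl carbon, such as isopropyl or a longer chain, and whether a ring or an amine placed there would follow the same direction. They also leave open whether the methyl for tert-butyl change gives a similar step when the butyl ester is replaced by the ethyl ester or by a carboxylic acid.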